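A Pentafluorophenyl Swap at a Level Baseline

This account rests on a few compounds, and the source may have more. Where it says the series, first, only, none or still open, it means among the compounds named here.

Two measured compounds set the baseline in a functional assay on DU-145 cells (Homo sapiens) for inhibition, read by trypan blue exclusion, with a stated time of 96 h; on this read-out lower numbers stand for stronger inhibition of growth and higher numbers for weaker inhibition of growth. Compound 1 (`O=C(/C(=C\c1ccc(O)c([N+](=O)[O-])c1)SCc1ccc(Br)cc1)c1c(F)c(F)c(F)c(F)c1F`) gives 10000 nM in this test, and compound 2 (`O=C(O)c1ccc(C(=O)/C(=C\c2ccc([N+](=O)[O-])c(O)c2)SCc2ccc(Br)cc2)cc1`) gives 10000 nM on the same read-out, so compound 2 stands level with compound 1. Compound 3 (`O=C(/C(=C\c1ccc([N+](=O)[O-])c(O)c1)SCc1ccc(Br)cc1)c1c(F)c(F)c(F)c(F)c1F`) differs from compound 2 by having 2,3,4,5,6-pentafluorophenyl in place of 4-carboxyphenyl on a carbonyl carbon. Compound 1 also carries the 2,3,4,5,6-pentafluorophenyl group and gives 10000 nM in this test, so no step beyond the scatter is expected in this assay. The estimated change is only a 1.3-fold lower number from compound 2 to compound 3 (0.10 log units; within the scatter) and remains an expectation until measured. For compound 3, the estimated value is 8000 nM (expected range 2000 nM to 20000 nM) in this test.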

Compound 3, concentration for 50% growth inhibition: 10000 nM
The estimate for compound 3 lay 1.3-fold (0.10 log units) below the measured number; measured number inside the range.
By their numbers in this assay, from the lowest: compounds 1, 2 and 3 (each within the scatter of the next).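

In this assay, 2,3,4,5,6-pentafluorophenyl in place of 4-carboxyphenyl on a carbonyl carbon gives no change at the digits printed from compound 2 to compound 3 (within the scatter) and so leaves the reading at the level already set, even though the entering group has no hydrogen-bond donor or acceptor and the leaving group has one of each. The second new step, 3-hydroxy-4-nitrophenyl in place of 4-hydroxy-3-nitrophenyl on a double-bonded chain carbon bound to a double-bonded chain carbon, gives no change at the digits printed from compound 1 to compound 3 (within the scatter), so neither change separates these compounds on this read-out. Nothing available explains this flat result.

The compounds shown leave open whether any other group on that carbonyl carbon, such as an amine or a longer chain, would move the number from this level. They also leave open whether a change elsewhere on the shared core would do so.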